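Trimming one methoxy from the ketone-side aryl ring

The source may report more compounds than this note shows. Statements on the series, on what has been measured and on what is new or still open speak of the compounds shown alone.

Measured compounds:
compound 1, `COc1cc(-c2cc(/C=C/C(=O)c3ccc(N)cc3)[nH]n2)cc(OC)c1OC`, -61%
compound 2, `COc1cc(-c2cc(/C=C/C(=O)c3ccc(Cl)c(Cl)c3)[nH]n2)cc(OC)c1OC`, 67%
compound 3, `COc1ccc(C(=O)/C=C/c2cc(-c3cc(OC)c(OC)c(OC)c3)n[nH]2)cc1OC`, -95%

Of the compounds shown here, three sharing one core have been tested in a functional assay on ACHN cells (Homo sapiens) for cytotoxicity, read by sulforhodamine B assay, with a stated time of 48 h, tested at 10 uM; a lower number here means a stronger effect, a higher number a weaker effect of the compound at the concentration tested. Compound 3 gives -95%, the lowest number of the three; its nearest neighbour is compound 1 with -61%, and compound 2 with 67% lies furthest from it. Every measured step replaces the whole aryl group on the carbonyl carbon: a number 128 percentage points higher from compound 1 to compound 2 (beyond the scatter); a number 34 percentage points lower from compound 1 to compound 3 (beyond the scatter); a number 162 percentage points lower from compound 2 to compound 3 (beyond the scatter). The numbers therefore move strongly with that ring.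

Compound 4, `COc1ccc(C(=O)/C=C/c2cc(-c3cc(OC)c(OC)c(OC)c3)n[nH]2)cc1`, differs from compound 3 by a smaller change: hydrogen in place of methoxy on an aromatic carbon. Within the data shown here, no measured step bears directly on this change; the three steps swap the whole ring rather than one methoxy, so they show only that this part of the molecule can shift this assay by large amounts. With the 3,4-dimethoxyphenyl of compound 3 standing lowest, a move upward is expected for compound 4 in this assay, estimated at a number 30 percentage points higher from compound 3 to compound 4 (beyond the scatter). Compound 4 is therefore estimated at -65%, within -100% to -10%.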

Compound 4, a percentage reported as activity, at one concentration (the size of the read-out at that concentration, not a potency): -83%
Compound 4: middle estimate off by 18 percentage points, on the high side; the measured number falls inside the stated range.
By their numbers in this assay, from the lowest: compound 3; then compound 4; then compound 1; then compound 2.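

In this assay the change from 3,4-dimethoxyphenyl to 4-methoxyphenyl alters this ring by a single group, and hydrogen in place of methoxy gives only a modest shift (a number 12 percentage points higher from compound 3 to compound 4 (beyond the scatter)), so the number stays strongly negative with one methoxy left. The 4-methoxyphenyl ring also keeps its large distance from the 3,4-dichlorophenyl ring (a number 150 percentage points lower from compound 2 to compound 4 (beyond the scatter)), while methoxy in place of amino on an aromatic carbon gives a modest step in the same direction (a number 22 percentage points lower from compound 1 to compound 4 (beyond the scatter)). No supporting data explain these shifts.

The compounds shown leave open whether a hydroxyl or an ethoxy group at the position of the lost methoxy would hold the number as low. They also leave open what an unsubstituted phenyl ring or a 4-dimethylaminophenyl ring on the carbonyl carbon would give.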